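A few compounds are considered here, and "the series" means these few. Any claim that something is new, unique, unknown or untested is made for them only; others in the source may bear on it.

Measured so far: compound 1 `OC[C@H]1O[C@@H](n2cnc3c(NCc4ccc(Cl)cc4)ncnc32)[C@H](O)[C@@H]1O` gives 1700 nM in a functional assay on HL-60 cells (Homo sapiens) for antiproliferative activity, with a stated time of 72 h; a lower number here means a stronger inhibitor, a higher number a weaker inhibitor; compound 2 `COc1ccccc1CNc1ncnc2c1ncn2[C@@H]1O[C@H](CO)[C@@H](O)[C@H]1O` gives 2300 nM; compound 3 `OC[C@H]1O[C@@H](n2cnc3c(NCc4ccc(Cl)c(Cl)c4)ncnc32)[C@H](O)[C@@H]1O` gives 2000 nM.

Compound 3 holds the second-highest of the three numbers, and both a 1.2-fold lower number from compound 2 to compound 3 (0.06 log units; within the scatter) and a 1.2-fold higher number from compound 1 to compound 3 (0.07 log units; within the scatter) sit within the scatter. Compound 4 `Cc1cccc(CNc2ncnc3c2ncn3[C@@H]2O[C@H](CO)[C@@H](O)[C@H]2O)c1O` has not yet been measured; it differs from compound 3 in one place: 2-hydroxy-3-methylphenyl in place of 3,4-dichlorophenyl on a saturated chain carbon bound to a nitrogen on an aromatic ring. Among the measured compounds shown here, the steps that bear on this swap of the aryl group are a 1.4-fold higher number from compound 1 to compound 2 (0.13 log units; within the scatter) and a 1.2-fold lower number from compound 2 to compound 3 (0.06 log units; within the scatter), with a 1.2-fold higher number from compound 1 to compound 3 (0.07 log units; within the scatter) also within the scatter. For the measured compounds named here, no measured compound carries a hydroxy or methyl on that ring, so the expectation rests only on these small aryl steps. Compound 4 is therefore expected to give 2000 nM, between 900 nM and 4500 nM. The expected step is no change at the digits printed from compound 3 to compound 4 (within the scatter), within the scatter.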

Compound 4, half-maximal inhibitory concentration: 15000 nM
Beside the measured number, compound 4's estimate is 7.5-fold (0.88 log units) below it, outside the stated range (above it).
By their numbers in this assay, from the lowest: compounds 1, 3 and 2 (each within the scatter of the next); then compound 4.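

In this assay the group on a saturated chain carbon bound to a nitrogen on an aromatic ring turns out to matter: 2-hydroxy-3-methylphenyl gives a 7.5-fold higher number from compound 3 to compound 4 (0.88 log units; beyond the scatter) and a 6.5-fold higher number from compound 2 to compound 4 (0.81 log units; beyond the scatter) and an 8.8-fold higher number from compound 1 to compound 4 (0.95 log units; beyond the scatter), all beyond the scatter, while compound 1, compound 2 and compound 3 stay within the scatter of one another. Of the four, only compound 4 has a hydrogen-bond donor in this group. Nothing measured here accounts for the higher number. From the compounds shown here alone, whether the hydroxy or the methyl drives the step remains open, as does the effect of an amine or a carboxylic acid on this ring.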